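Notes on the step from compound 1 to compound 4

The source may hold more compounds than are shown below. What is called first, only, known or untested is meant among the compounds shown, and "the series" means these compounds.

Compound 1 `CCCCCCCCS(=O)(=O)Nc1cc(-c2ccccc2Cl)ccc1C(=O)O` gives 26900 nM in an assay on mitochondria (strain BALB/c) for inhibition of glycerol-3-phosphate acyltransferase 1, mitochondrial (Mus musculus), read by scintillation counting, with a stated time of 10 min (on this read-out higher numbers stand for weaker inhibition and lower numbers for stronger inhibition), the lowest number of the three measured. Compound 3 `CCCCCCCCS(=O)(=O)Nc1ccc(/C=C/c2ccc(OC)cc2)cc1C(=O)O` gives 37100 nM, a value within the scatter of compound 1, while compound 2 `CCCCCCCCS(=O)(=O)Nc1ccc(C(=O)c2ccccc2OC)cc1C(=O)O` gives 59200 nM, beyond it. Among the compounds with values here, the only measured step is a 1.6-fold lower number from compound 2 to compound 3 (0.20 log units; within the scatter); it exchanges one group bearing a six-membered aromatic ring of carbon only for another and stays within the scatter. Compound 4 `CCCCCCCCS(=O)(=O)Nc1cc(CCc2ccccc2)ccc1C(=O)O` differs from compound 1 by phenethyl in place of 2-chlorophenyl on an aromatic carbon. That measured step bears on this change only loosely, as a like-for-like exchange of such groups, and gives no ground to expect a step beyond the scatter. The number for compound 4 is therefore expected near 27000 nM, between 10000 nM and 70000 nM. This amounts to an expected 1.0-fold higher number from compound 1 to compound 4 (0.00 log units; within the scatter).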

Compound 4, half-maximal inhibitory concentration: 37500 nM
Beside the measured number, compound 4's estimate is 1.4-fold (0.14 log units) below it, and the stated range covers the measured number.
By their numbers in this assay, from the lowest: compounds 1, 3, 4 and 2 (each within the scatter of the next, the first and the last beyond it).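

At the aromatic carbon para to a carboxy group, phenethyl in place of 2-chlorophenyl gives a 1.4-fold higher number from compound 1 to compound 4 (0.14 log units; within the scatter) in this assay. The two groups, each carrying one six-membered aromatic ring of carbon only, are therefore not told apart at this position by this read-out. No supporting data bear on this result.

On these data alone, whether an amine or a carboxylic acid at this position would give a step beyond the scatter remains open. So does the effect of a longer chain in place of phenethyl.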